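Swapping the chloro group for an amine-bearing ether

The source may hold more compounds than are shown below. What is called first, only, known or untested is meant among the compounds shown, and "the series" means these compounds.

Compound 1 `Cc1cnc(C(=O)Nc2cc(Cl)cc3cccnc23)cn1`: 1770 nM
Compound 2 `O=C(Nc1cc(Cl)cc2cccnc12)c1cnccn1`: 2700 nM
Compound 3 `O=C(Nc1cc(Cl)cc2cccnc12)c1ncccn1`: 4670 nM

All three were tested in a functional assay on PANC-1 cells (Homo sapiens) for inhibition, read by MTT assay, with a stated time of 72 h; a higher number here means a weaker inhibitor, a lower number a stronger inhibitor. Compound 1 has the lowest number of the three: the step of a 1.5-fold higher number from compound 1 to compound 2 (0.18 log units; within the scatter) stays within the scatter, whereas the step of a 2.6-fold higher number from compound 1 to compound 3 (0.42 log units; beyond the scatter) lies beyond it. Compound 4 `Cc1cnc(C(=O)Nc2cc(OCCN)cc3cccnc23)cn1` differs from compound 1 by 2-aminoethoxy in place of chloro on an aromatic carbon. Going by the values given here, no measured step bears on this position; the changes seen so far, such as a 1.7-fold higher number from compound 2 to compound 3 (0.24 log units; within the scatter), all concern the group on the carbonyl carbon, so the data give no direction for this change. A modest weakening is therefore expected only as a cautious guess, with wide uncertainty: compound 4 is estimated at 3500 nM, ranging from 900 nM to 14000 nM. This estimate means an expected step of a 2.0-fold higher number from compound 1 to compound 4 (0.30 log units; within the scatter).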

Compound 4, half-maximal inhibitory concentration: > 10000 nM
Compound 4: a limit, no number; the forecaster's own chance of this, stated with the estimate: 10%; at least 2.8-fold (0.45 log units) between middle value and limit.
By their numbers in this assay, from the lowest: compounds 1, 2 and 3 (each within the scatter of the next, the first and the last beyond it). At a limit, above all of these: compound 4.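

So far only the group on the carbonyl carbon had varied, and this first change on the aromatic carbon that carries chloro shows that this position is not indifferent to substitution. Putting 2-aminoethoxy in place of chloro gives an at least 5.6-fold higher number from compound 1 to compound 4 (0.75 log units; beyond the scatter). Compound 4 reads > 10000 nM, which is a limit and not a number, so only the minimum size of this step is known.

The compounds shown leave open whether the terminal amine or the ether chain accounts for this loss. A methoxy group or a 2-hydroxyethoxy chain at this position could separate the two.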